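A few compounds are considered here, and "the series" means these few. Any claim that something is new, unique, unknown or untested is made for them only; others in the source may bear on it.

In a functional assay on MCF7 cells (Homo sapiens) for inhibition, read by sulforhodamine B assay (a lower number here means a stronger inhibitor, a higher number a weaker inhibitor), compound 1 `O=C1C=C(NCc2ccccc2)C(=O)c2c1nc1n2[C@H]2OC[C@@H](O)[C@H]2OC1`, which carries a benzyl group on an amine nitrogen, reads > 8000 nM. That reading is a limit of the assay and not a number. Two related compounds do give numbers: compound 2 `O=C1C(Nc2ccc(Br)cc2)=CC(=O)c2c1nc1n2[C@H]2OC[C@@H](O)[C@H]2OC1`, which carries a 4-bromophenyl group, reaches 4330 nM, and compound 3 `CCc1ccc(NC2=CC(=O)c3c(nc4n3[C@H]3OC[C@@H](O)[C@H]3OC4)C2=O)cc1` reaches 8990 nM. The step between them, with ethyl in place of bromo on an aromatic carbon, is a 2.1-fold higher number from compound 2 to compound 3 (0.32 log units; beyond the scatter).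

The change to compound 4 `O=C1C=C(Nc2ccc(Br)cc2)C(=O)c2c1nc1n2[C@H]2OC[C@@H](O)[C@H]2OC1` is 4-bromophenyl in place of benzyl on an amine nitrogen. Among the compounds with values here, no measured step covers this swap directly, and compound 1 offers no number to start from. The closest guides are compound 2, which has the same 4-bromophenyl group, at 4330 nM, and the modest size of a 2.1-fold higher number from compound 2 to compound 3 (0.32 log units; beyond the scatter). A modest move towards a lower number in this assay is therefore expected, and the estimated step is an at least 1.6-fold lower number from compound 1 to compound 4 (0.20 log units; that floor lies within the scatter). The expected value for compound 4 is 5000 nM, within a range of 1800 nM to 14000 nM.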

Compound 4, half-maximal inhibitory concentration: 2580 nM
Beside the measured number, compound 4's estimate is 1.9-fold (0.29 log units) above it; measured number inside the range.
By their numbers in this assay, from the lowest: compounds 4 and 2 (each within the scatter of the next); then compound 3.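

In this assay, the swap of benzylamino for (4-bromophenyl)amino gives an at least 3.1-fold lower number from compound 1 to compound 4 (0.49 log units; beyond the scatter). Within the data shown here, this is the first reading at this position that yields a number, and it shows that this position responds to the group on the amine nitrogen, even though the entering and leaving groups have the same count of heavy atoms and each holds one aromatic ring of carbon. The step can only be stated as a floor, because the reading for compound 1 is a limit and not a number: the limit of > 8000 nM in this assay, at which 1 of the 4 values shown sits.

The compounds shown do not separate the two parts of this change, the added bromine and the shorter link to the ring. A plain phenyl group or a 4-bromobenzyl group on this amine nitrogen would tell those two parts apart.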